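The compounds below may be only part of what the source reports. "The series", "measured", "known", "first", "only" and "open" are said of these compounds alone.

Three compounds sharing one core have been examined in a toxicity assay on Vero cells (Chlorocebus sabaeus) for cytotoxicity, read by MTT assay; a lower number here means a stronger inhibitor, a higher number a weaker inhibitor. Compound 1 `COC(=O)NC(=O)c1ccsc1NC(=O)c1ccc(S(=O)(=O)N2CCCC2)cc1` gives 39.5 ug/mL. Compound 2 `COC(=O)NC(=O)c1ccsc1NC(=O)c1ccc(S(=O)(=O)N2CCC(c3ccccc3)CC2)cc1` gives "nd" (no result reported). Compound 3 `COC(=O)NC(=O)c1ccsc1NC(=O)c1ccc(S(=O)(=O)NC2CCCCC2)cc1` gives > 64 ug/mL, and this is a limit of the assay, not a number. Compound 4 `COC(=O)NC(=O)c1ccsc1NC(=O)c1ccc(S(=O)(=O)NC2CCC(F)(F)CC2)cc1` has not yet been measured and carries 4,4-difluorocyclohexyl in place of cyclohexyl on a sulfonamide nitrogen. For the measured compounds named here, the only measured step, an at least 1.6-fold higher number from compound 1 to compound 3 (0.20 log units; that floor lies within the scatter), involves a different swap, cyclohexylamino in place of pyrrolidin-1-yl, so it offers only weak guidance, and no shift beyond the scatter is expected in this assay. The expected change is a number no higher from compound 3 to compound 4 (the limit leaves the size open). Compound 4 is estimated at 64 ug/mL, with an expected range of 32 ug/mL to 100 ug/mL.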

Compound 4, half-maximal inhibitory concentration: 49 ug/mL
The estimate for compound 4 lay 1.3-fold (0.12 log units) above the measured number; low and high end bracket the measured number.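

With 4,4-difluorocyclohexyl in place of cyclohexyl on a sulfonamide nitrogen, this assay gives an at least 1.3-fold lower number from compound 3 to compound 4 (0.11 log units; that floor lies within the scatter), so this change shows no shift beyond the scatter. From the compounds shown here alone, the size of that step stays open because one end of it is a limit: the limit of > 64 ug/mL in this assay, at which 1 of the 4 values shown sits. Replacing pyrrolidin-1-yl on a sulfonyl sulfur with (4,4-difluorocyclohexyl)amino gives a 1.2-fold higher number from compound 1 to compound 4 (0.09 log units; within the scatter), which also lies within the scatter and leaves these two compounds unseparated. Going by these compounds, what an amine-bearing ring or an open butyl chain would give in place of cyclohexyl on a sulfonamide nitrogen remains open.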